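A few compounds are considered here, and "the series" means these few. Any claim that something is new, unique, unknown or untested is made for them only; others in the source may bear on it.

Measured compounds in a functional assay on the whole organism with Rattus norvegicus as the target; on this read-out higher numbers stand for an effect only at larger amounts of compound and lower numbers for an effect already at smaller amounts:
compound 1 `CCN(CCNC(=O)c1cc(Cl)c(N)cc1OC)Cc1ccc(OC)cc1` gives 0.2 mg/kg
compound 2 `CCN(CCNC(=O)c1cc(Cl)c(N)cc1OC)Cc1ccc(Cl)cc1` gives 0.24 mg/kg
compound 3 `COc1ccc(Cl)cc1C(=O)NCCN(C)Cc1ccccc1` gives 3 mg/kg

Compound 2 and compound 1 differ in one place, (methoxy in place of chloro on an aromatic carbon), and the step is a 1.2-fold lower number from compound 2 to compound 1 (0.08 log units; within the scatter). Compound 3 stands apart: the difference between its core and that of compound 2 is not broken down here, and its number is the highest of the three. Compound 4 `COc1ccc(OC)c(C(=O)NCCN(C)Cc2ccccc2)c1` is not yet measured; it comes from compound 3 by methoxy in place of chloro on an aromatic carbon. This is the same kind of change as from compound 2 to compound 1, but not the same: there the place was para to a large group, here it is meta to a large group and para to a methoxy group. Because a 1.2-fold lower number from compound 2 to compound 1 (0.08 log units; within the scatter) stayed within the scatter, the step expected for compound 4 is no change at the digits printed from compound 3 to compound 4 (within the scatter). The estimate for compound 4 is 3 mg/kg, expected to fall between 1.2 mg/kg and 7 mg/kg.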

Compound 4, dose for half-maximal effect: 3 mg/kg
Beside the measured number, compound 4's estimate shows no gap at the digits printed; low and high end bracket the measured number.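

In this assay, methoxy in place of chloro on an aromatic carbon gives no change at the digits printed from compound 3 to compound 4 (within the scatter), so on the core of compound 3 this swap leaves the number where it stood. The two cores agree on this change: the same change on two cores in this assay, a 1.2-fold lower number (0.08 log units; within the scatter) from compound 2 to compound 1 and no change at the digits printed (within the scatter) from compound 3 to compound 4, 1.2-fold (0.08 log units) apart, within the scatter of two such steps. This shows that the lack of a clear effect carried over from one core to the other, but it does not show that the same would hold on any further core, and two steps this small say nothing about why the number stays put.

The compounds shown leave open whether a different group in the same place, such as a nitrile or a carboxylic acid, would shift the number on either core.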